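Succinimide Piperazine Amides: Aryl Substituent Exchange

The compounds below may be only part of what the source reports. "The series", "measured", "known", "first", "only" and "open" are said of these compounds alone.

Compound 1 `CCC(C(=O)N1CCN(c2cccc(C(F)(F)F)c2)CC1)N1C(=O)CCC1=O` gives 0% in a functional assay on the whole organism (strain Swiss) with Mus musculus as the target, in the maximal electroshock model, with a stated time of 2 h, at a dose of 100 mg/kg by the intraperitoneal route; on this read-out lower numbers stand for a weaker effect and higher numbers for a stronger effect at the one dose given. Compound 2 `CC(C(=O)N1CCN(c2cccc(C(F)(F)F)c2)CC1)N1C(=O)CCC1=O` gives 0% in this assay, so compound 1 stands level with compound 2. Among the compounds with values here, the only measured step, no change at the digits printed from compound 1 to compound 2 (within the scatter), concerns the saturated chain and not the aromatic ring. Compound 3 `CCC(C(=O)N1CCN(c2cccc(Cl)c2)CC1)N1C(=O)CCC1=O` differs from compound 1 by chloro in place of trifluoromethyl on an aromatic carbon. Within the data shown here, no measured step touches the aromatic substituent, so there is no direct guide for this change. Because compound 1 sits at 0%, a step of no change at the digits printed from compound 1 to compound 3 (within the scatter) is expected, none beyond the scatter. Compound 3 is therefore estimated at 0%, between 0% and 10%.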

Compound 3, a percentage reported as activity, at one dose (the size of the read-out at that dose, not a potency): 0%
Beside the measured number, compound 3's estimate shows no gap at the digits printed; the measured number falls inside the stated range.
By their numbers in this assay, from the lowest: compounds 1, 2 and 3 (each within the scatter of the next).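

In this assay the aromatic substituent gets its first reading, with no change at the digits printed from compound 1 to compound 3 (within the scatter) for chloro in place of trifluoromethyl on an aromatic carbon. Within the data shown here, this exchange, like the chain step, therefore separates no compounds on this read-out, and a difference between the two groups cannot be read while both compounds show no effect at the one dose given. No evidence on the cause of this result is available.

On these data alone, whether a methoxy group or an amine at this aromatic carbon would give any effect remains open. So does whether a longer chain on the saturated carbon would do so.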